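Lengthening the sulfur side chain of compound 1

The compounds below may be only part of what the source reports. "The series", "measured", "known", "first", "only" and "open" are said of these compounds alone.

In a functional assay on MV4-11 cells (Homo sapiens) for inhibition, read by resazurin assay, with a stated time of 72 h (on this read-out lower numbers stand for stronger inhibition of growth and higher numbers for weaker inhibition of growth), compound 1 `COc1ccc(Nc2nccc(-c3sc(SC)nc3C)n2)c(OC)c1` gives 530 nM as the lowest of three numbers. Compound 2 `COc1ccc(Nc2nccc(-c3cn(C(C)C)c4ccccc34)n2)c(OC)c1` stands at 3250 nM and compound 3 `CCCn1cc(-c2ccnc(Nc3ccc(OC)cc3OC)n2)c2ccccc21` at 3620 nM with both numbers clearly higher than that of compound 1. Compound 4 `COc1ccc(Nc2nccc(-c3sc(SCCCN(C)C)nc3C)n2)c(OC)c1` differs from compound 1 by 2-(dimethylamino)ethyl in place of hydrogen on a saturated chain carbon bound to a sulfur and this change sits on a saturated chain carbon bound to a sulfur. Within the data shown here, the only measured step is a 1.1-fold higher number from compound 2 to compound 3 (0.05 log units; within the scatter) for propyl in place of isopropyl on an aromatic nitrogen. That step lies within the scatter and bears only loosely on a change made elsewhere. The step expected in this assay is a 1.2-fold lower number from compound 1 to compound 4 (0.07 log units; within the scatter) and thus none beyond the scatter. For compound 4 the estimated value is 450 nM with an expected range of 130 nM to 1600 nM as a rough guide.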

Compound 4, concentration for 50% growth inhibition: 370 nM
Estimate against measurement, compound 4: 1.2-fold (0.09 log units) above; the measured number falls inside the stated range.
By their numbers in this assay, from the lowest: compounds 4 and 1 (each within the scatter of the next); then compounds 2 and 3 (each within the scatter of the next).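

In this assay, the first change shown on a saturated chain carbon bound to a sulfur gives a 1.4-fold lower number from compound 1 to compound 4 (0.16 log units; within the scatter). Replacing methylsulfanyl with (3-(dimethylamino)propyl)sulfanyl therefore adds 5 heavy atoms, including a nitrogen, without moving the number beyond the scatter. Nothing available explains this result. On these data alone, it remains open whether a carboxylic acid in place of the dimethylamino group, or a longer chain, would also leave the number within the scatter of compound 1.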